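The source may report more compounds than this note shows. Statements on the series, on what has been measured and on what is new or still open speak of the compounds shown alone.

Of the compounds shown here, two have been measured in an assay on CHO cells for displacement of a labelled ligand from Substance-P receptor (Homo sapiens); a higher number here means a weaker inhibitor, a lower number a stronger inhibitor. Compound 1 `C[C@@H](OCC1(c2ccccc2)CC(NCc2n[nH]c(O)n2)C1)c1cc(C(F)(F)F)cc(C(F)(F)F)c1` gives 0.5 nM. Compound 2 `C[C@@H](OC[C@]1(c2ccccc2)C[C@](N)(C(=O)N2CCCCC2)C1)c1cc(C(F)(F)F)cc(C(F)(F)F)c1` gives 1.3 nM, the higher of the two numbers, and its gap to compound 1 lies beyond the scatter. Compound 3 `C[C@@H](OC[C@]1(c2ccccc2)C[C@](N)(C(=O)N2CCCC2)C1)c1cc(C(F)(F)F)cc(C(F)(F)F)c1` differs from compound 2 in one place only: pyrrolidin-1-yl in place of piperidin-1-yl on a carbonyl carbon. Among the compounds with values here, no measured pair shows this change, so nothing here tells how it acts. The step expected from this change, a 1.2-fold higher number from compound 2 to compound 3 (0.06 log units; within the scatter), is none beyond the scatter, with no direction favoured. Compound 3 is therefore estimated at 1.5 nM, within a range from 0.5 nM to 4.5 nM.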

Compound 3, inhibition constant: 1.3 nM
Compound 3: middle estimate off by 1.2-fold (0.06 log units), on the high side; low and high end bracket the measured number.
By their numbers in this assay, from the lowest: compound 1; then compounds 2 and 3 (each within the scatter of the next).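

In this assay, within the data shown here, this pair gives the first direct reading of the change at this position: pyrrolidin-1-yl in place of piperidin-1-yl on a carbonyl carbon gives no change at the digits printed from compound 2 to compound 3 (within the scatter) and so shows that, for these two compounds, either ring can stand here with no step beyond the scatter. No available measurement explains this result. The compounds shown leave open whether azepan-1-yl, morpholin-4-yl or an open-chain dimethylamino group on the same carbonyl carbon would also leave the number within the scatter.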